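The compounds below may be only part of what the source reports. "The series", "measured", "known", "first", "only" and "open" are said of these compounds alone.

Measured compounds in an assay on HEK293 cells for inhibition of Voltage-dependent T-type calcium channel subunit alpha-1G (Homo sapiens), read by fluorescence, tested at 10 uM; a higher number here means more inhibition at the concentration tested (going by the name of the read-out), a lower number less inhibition:
compound 1 `CCCc1nc(-c2ccccc2)c(CNCCCN2CCN(c3ccccc3F)CC2)o1`: 54.4%
compound 2 `CCCc1nc(-c2ccccc2)c(CNCCN2CCN(c3ccc(C)cc3)CC2)o1`: 48.1%
compound 3 `CCCc1nc(-c2ccccc2)c(CNCCCN2CCN(c3ccc(F)cc3)CC2)o1`: 62.5%

Compound 2 holds the lowest of the three numbers in this assay; compound 1 sits nearest, within the scatter, and compound 3 furthest, beyond it. Compound 4 `CCCc1nc(-c2ccccc2)c(CNCCN2CCN(c3ccccc3C)CC2)o1`, not yet measured, differs from compound 2 by 2-methylphenyl in place of 4-methylphenyl on an amine nitrogen in a ring. Within the data shown here, the only measured step that bears on this is a number 8.1 percentage points higher from compound 1 to compound 3 (within the scatter), which goes from 2-fluorophenyl to 4-fluorophenyl on the same ring nitrogen, the reverse sense of the present change, and stays within the scatter. Read backwards it suggests at most a small drop, not beyond the scatter. The step expected is a number 6.1 percentage points lower from compound 2 to compound 4 (within the scatter). Compound 4 is therefore estimated at 42%, range 25% to 60%.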

Compound 4, a percentage reported as inhibition, at one concentration (the size of the read-out at that concentration, not a potency): 51.3%
Compound 4: middle estimate off by 9.3 percentage points, on the low side; measured number inside the range.
By their numbers in this assay, from the lowest: compounds 2, 4, 1 and 3 (each within the scatter of the next, the first and the last beyond it).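

On the amine nitrogen in the ring, 2-methylphenyl in place of 4-methylphenyl gives in this assay a number 3.2 percentage points higher from compound 2 to compound 4 (within the scatter), so the methyl group can occupy either position on the phenyl ring without a change that can be read. Alongside a number 8.1 percentage points higher from compound 1 to compound 3 (within the scatter), this makes two pairs in which the substituent position on the phenyl ring leaves the number within the scatter, so the number is level in both pairs. Nothing available explains this result.

Still open, on these data alone, is whether a methoxy group or chlorine on this phenyl ring, or an unsubstituted phenyl, would move the number beyond the scatter.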